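The source may hold more compounds than are shown below. What is called first, only, known or untested is meant among the compounds shown, and "the series" means these compounds.

Measured compounds in a functional assay on Jurkat cells (Homo sapiens) for inhibition; a lower number here means a stronger inhibitor, a higher number a weaker inhibitor:
Compound 1 `CCCCCCCCCCCCCCC(COCc1ccccc1)NCC` gives 6000 nM.
Compound 2 `CCCCCCCCCCCCCCC(COCc1ccccc1)NCC(=O)O` gives 3000 nM.
Compound 3 `CCCCCCCCCCCCCCC(COCc1ccccc1)NC(=O)CCCC(=O)O` gives > 50000 nM, which is a limit of the assay and not a number.

Compound 3 thus stands at the limit of this assay, as one of the three values shown (the limit of > 50000 nM in this assay, at which 1 of the 3 values shown sits). The step of an at least 8.3-fold higher number from compound 1 to compound 3 (0.92 log units; beyond the scatter) and the step of an at least 16-fold higher number from compound 2 to compound 3 (1.22 log units; beyond the scatter) both run in the direction of a weaker inhibitor, while the step of a 2.0-fold lower number from compound 1 to compound 2 (0.30 log units; within the scatter) stays within the scatter.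

Compound 4 `CCCCCCCCCCCCCCC(COCc1ccccc1)NC(=O)CCC(=O)O` differs from compound 3 by carboxy in place of carboxymethyl on a saturated chain carbon, two bonds along the chain from a carbonyl carbon. Among the compounds with values here, no measured step addresses this change directly; the closest is the step of a 2.0-fold lower number from compound 1 to compound 2 (0.30 log units; within the scatter), where a carboxy also enters on a saturated chain carbon, and it stayed within the scatter. The two steps leading into compound 3 show that a chain-carboxylic acyl group on the amine nitrogen is what carried the number to the limit, and compound 4 retains such a group, one carbon shorter. The expected step that the limit leaves unreadable from compound 3 to compound 4 is therefore none beyond the scatter. For compound 4 the estimate in this assay is 60000 nM, with a range from 20000 nM to 200000 nM, most likely reported again as a limit.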

Compound 4, half-maximal inhibitory concentration: 30000 nM
Compound 4: the middle estimate sits 2.0-fold (0.30 log units) above what was measured; low and high end bracket the measured number.
By their numbers in this assay, from the lowest: compounds 2 and 1 (each within the scatter of the next); then compound 4. At a limit, above all of these: compound 3.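

In this assay, (2-carboxyethyl)carbonyl on the amine nitrogen gives the series its first acyl group with a measured number, so the cost of this change now has a size and not only a floor: the steps are a 10-fold higher number from compound 2 to compound 4 (1.00 log units; beyond the scatter) and a 5.0-fold higher number from compound 1 to compound 4 (0.70 log units; beyond the scatter). Cutting the acyl chain from (3-carboxypropyl)carbonyl to (2-carboxyethyl)carbonyl gives an at least 1.6-fold lower number from compound 3 to compound 4 (0.22 log units; that floor lies within the scatter), which does not establish any real effect of chain length at this position. Compound 3 is a limit of the assay and not a number, so this step has only a floor and no size: the limit of > 50000 nM in this assay, at which 1 of the 4 values shown sits.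

Still open, as far as these compounds go, is whether the carbonyl or the chain length carries the loss, since 2-carboxyethyl placed directly on the amine nitrogen would separate the two when set against compound 2 and compound 4. Also open, from the compounds shown here alone, is what the terminal carboxylic acid contributes to the acylated compounds, a question that a plain butanoyl group on the same nitrogen, compared with compound 4, would address.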